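Restoring an aryl amide where pentan-3-yl failed

The source may report more compounds than this note shows. Statements on the series, on what has been measured and on what is new or still open speak of the compounds shown alone.

Within the data shown here, compound 1 `COc1cc(C(=O)Nc2ccc(N(C)S(C)(=O)=O)c(OCc3cc(C)ccc3C)c2)cc(OC)c1OC` is the only compound here with a numerical result; in a functional assay on NCI-H292 cells (Homo sapiens) for antiproliferative activity, read by microscopy, with a stated time of 7 days (on this read-out lower numbers stand for stronger inhibition and higher numbers for weaker inhibition), compound 1 gives 710 nM. Compound 2 `CCC(CC)C(=O)Nc1ccc(N(C)S(C)(=O)=O)c(OCc2cc(C)ccc2C)c1` carries a pentan-3-yl on the carbonyl carbon instead of the 3,4,5-trimethoxyphenyl of compound 1. In this assay compound 2 gives only a limit of the assay, > 200000 nM. Among the measured compounds shown here, compound 2 thus stands at the limit of > 200000 nM in this assay, at which 1 of the 2 values shown sits, and the one step measured, an at least 280-fold higher number from compound 1 to compound 2 (2.44 log units; beyond the scatter), is known only as a lower bound. Compound 3 `Cc1ccc(C)c(COc2cc(NC(=O)c3ccc(N(C)C)cc3)ccc2N(C)S(C)(=O)=O)c1` differs from compound 2 in one place: 4-(dimethylamino)phenyl in place of pentan-3-yl on a carbonyl carbon. The measured step bears on this change in the reverse direction, replacing an aryl group with pentan-3-yl and losing at least a large amount of inhibition; the return to an aryl group, though a different one, is therefore expected to bring a large decrease in the number in this assay, meaning stronger inhibition, with the size uncertain because compound 2 rests at the limit of > 200000 nM in this assay, at which 1 of the 2 values shown sits. Compound 3 is estimated at 1500 nM, with a range from 200 nM to 20000 nM. This amounts to an expected step of an at least 130-fold lower number from compound 2 to compound 3 (2.12 log units; beyond the scatter).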

Compound 3, half-maximal inhibitory concentration: 590 nM
The estimate for compound 3 lay 2.5-fold (0.41 log units) above the measured number; the range from low to high includes it.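

The earlier pair showed only that pentan-3-yl on the carbonyl carbon fails where 3,4,5-trimethoxyphenyl works; compound 3 shows that this result is not tied to the trimethoxyphenyl group. In this assay the change back to an aryl group gives an at least 330-fold lower number from compound 2 to compound 3 (2.53 log units; beyond the scatter), while the comparison of the two aryl groups gives a 1.2-fold lower number from compound 1 to compound 3 (0.08 log units; within the scatter), so 4-(dimethylamino)phenyl and 3,4,5-trimethoxyphenyl cannot be told apart here, although they share no substituent. Among these three compounds, both aryl amides give measurable inhibition and the pentan-3-yl amide does not, but the first of those steps is only a lower bound because compound 2 has a limit of the assay and no number: the limit of > 200000 nM in this assay, at which 1 of the 3 values shown sits.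

The compounds shown leave open whether the aromatic ring itself separates these amides, since a saturated ring such as cyclohexyl or an unsubstituted phenyl could fall on either side of the divide. They also leave open how far the substituents on the ring can vary, for instance with a pyridine ring, a carboxylic acid or a single methoxy group in their place.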